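Series notes: N-alkyl variation on the indole nitrogen

This account rests on a few compounds, and the source may have more. Where it says the series, first, only, none or still open, it means among the compounds named here.

Going by the values given here, compound 2 `Cn1ccc2cc(-c3ccn4c(CC(F)(F)F)cnc4c3C#N)cc(Cl)c21` stands highest of the two numbers so far in a functional assay on CHO cells for agonist activity at metabotropic glutamate receptor 2 (Homo sapiens) (a higher number here means a larger maximal response, a lower number a smaller maximal response), where compound 2 gives 184%; compound 1 `Cn1ccc2cc(-c3ccn4c(CC(F)(F)F)cnc4c3C#N)ccc21` gives 154% in this assay, the step of a number 30 percentage points higher from compound 1 to compound 2 (beyond the scatter). Compound 3 `N#Cc1c(-c2cc(Cl)c3c(ccn3CC3CC3)c2)ccn2c(CC(F)(F)F)cnc12` differs from compound 2 by cyclopropyl in place of hydrogen on a saturated chain carbon bound to an aromatic nitrogen. Among the compounds with values here, the only measured step concerns a chloro replacing hydrogen on an aromatic carbon and does not bear on the group on the nitrogen-bound chain carbon; no measured pair tests this position. The expected step of a number 4 percentage points lower from compound 2 to compound 3 (within the scatter) is therefore none beyond the scatter. Compound 3 is estimated at 180%, within 140% to 220%.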

Compound 3, largest response reached (Emax), in percent of the reference or control that the assay uses: 200%
Compound 3: middle estimate off by 20 percentage points, on the low side, and the stated range covers the measured number.
By their numbers in this assay, from the lowest: compound 1; then compound 2; then compound 3.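

Methyl to cyclopropylmethyl is the first change read at the saturated chain carbon bound to an aromatic nitrogen, and in this assay it gives a number 16 percentage points higher from compound 2 to compound 3 (beyond the scatter). The position therefore accepts cyclopropyl with the maximal response still rising, a gain read only on the chloro-bearing core. Nothing measured gives a reason for this rise.

On these data alone, whether the same change raises the response on the core of compound 1 remains open. So does the outcome with a longer chain, such as n-butyl, or with a chain ending in an amine.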